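Furan-2-yl to 1-benzofuran-2-yl: a step from a limit

The source may report more compounds than this note shows. Statements on the series, on what has been measured and on what is new or still open speak of the compounds shown alone.

Every reading so far in a functional assay on CCRF-CEM cells (Homo sapiens), read by MTT assay, with a stated time of 72 h (on this read-out lower numbers stand for stronger inhibition and higher numbers for weaker inhibition), is a limit, not a number. Compound 1 `CN(C)c1ncnc2c1c(-c1cc3ccccc3o1)cn2[C@@H]1O[C@H](CO)[C@@H](O)[C@H]1O`, which already bears 1-benzofuran-2-yl, reads > 20000 nM, a limit. Compound 2 `C#Cc1cn([C@@H]2O[C@H](CO)[C@@H](O)[C@H]2O)c2nc(N)nc(OC)c12` reads > 100000 nM, also a limit. Compound 3 `Nc1nc2c(c(-c3ccco3)cn2[C@@H]2O[C@H](CO)[C@@H](O)[C@H]2O)c(=O)[nH]1` reads > 20000 nM, again a limit, so it has no exact value.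

Compound 4 `Nc1nc2c(c(-c3cc4ccccc4o3)cn2[C@@H]2O[C@H](CO)[C@@H](O)[C@H]2O)c(=O)[nH]1` carries 1-benzofuran-2-yl in place of the furan-2-yl of compound 3, on an aromatic carbon (1-benzofuran-2-yl in place of furan-2-yl on an aromatic carbon). No measured step sizes this change. In this assay, no shift in either direction beyond the usual scatter is expected, and the estimated move is a number no higher from compound 3 to compound 4 (the limit leaves the size open). This expectation rests on compound 1, whose > 20000 nM is a limit. For compound 4 the estimate is 20000 nM, with an expected range of 6000 nM to 40000 nM.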

Compound 4, half-maximal inhibitory concentration: > 20000 nM
Compound 4 was reported as a limit (the forecaster's own chance of this, stated with the estimate: 75%); the middle value sits exactly at the limit.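

Compound 3 and compound 4 are both reported only as limits in this assay, so the step between them cannot be read: the limit of > 20000 nM in this assay, at which 3 of the 4 values shown sit.

The compounds shown leave open whether any group at this place gives an exact value in this assay.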